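Bromofluorophenyl in Place of Trifluoromethoxyphenyl on the Methylated Core

A few compounds are considered here, and "the series" means these few. Any claim that something is new, unique, unknown or untested is made for them only; others in the source may bear on it.

Among the compounds with values here, compound 3 `Cc1cc(=O)n(-c2ccccc2OC(F)(F)F)nc1C(=O)Nc1ccc(Oc2ncnc3c2ccn3C)cc1` gives 25200 nM in a functional assay on A549 cells (Homo sapiens) for cytotoxicity, read by MTT assay, with a stated time of 72 h (on this read-out lower numbers stand for stronger inhibition and higher numbers for weaker inhibition), the highest of the three numbers measured so far. Compound 1 `Cc1cc(=O)n(-c2ccccc2OC(F)(F)F)nc1C(=O)Nc1ccc(Oc2ncnc3[nH]ccc23)cc1` gives 16200 nM in this assay, and it differs from compound 3 only by a methyl in place of hydrogen on an aromatic nitrogen; that step is a 1.6-fold higher number from compound 1 to compound 3 (0.19 log units; within the scatter). Compound 2 `Cc1cc(=O)n(-c2ccc(Br)cc2F)nc1C(=O)Nc1ccc(Oc2ncnc3[nH]ccc23)cc1` gives 3770 nM in this assay. Compound 4 `Cc1cc(=O)n(-c2ccc(Br)cc2F)nc1C(=O)Nc1ccc(Oc2ncnc3c2ccn3C)cc1` differs from compound 3 by 4-bromo-2-fluorophenyl in place of 2-(trifluoromethoxy)phenyl on an aromatic nitrogen. The same change has been measured once, on the core without the methyl on the aromatic nitrogen: a 4.3-fold lower number from compound 1 to compound 2 (0.63 log units; beyond the scatter). That step bears directly on the present one, and the methyl change itself stayed within the scatter, so a step of similar size toward a lower number is expected here: a 4.2-fold lower number from compound 3 to compound 4 (0.62 log units; beyond the scatter). Compound 4 is therefore expected to give 6000 nM in this assay, with a range from 2500 nM to 15000 nM.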

Compound 4, half-maximal inhibitory concentration: 47300 nM
Estimate against measurement, compound 4: 7.9-fold (0.90 log units) below; the measured number lies above the stated range.
By their numbers in this assay, from the lowest: compound 2; then compounds 1, 3 and 4 (each within the scatter of the next, the first and the last beyond it).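

In this assay, the 4-bromo-2-fluorophenyl change does not carry over between the two cores; on the core with the methyl on the aromatic nitrogen, it gives a 1.9-fold higher number from compound 3 to compound 4 (0.27 log units; within the scatter), and the two steps disagree: the same change on two cores in this assay, a 4.3-fold lower number (0.63 log units; beyond the scatter) from compound 1 to compound 2 and a 1.9-fold higher number (0.27 log units; within the scatter) from compound 3 to compound 4, 8.1-fold (0.91 log units) apart, beyond the scatter of two such steps. The methyl change likewise depends on the group on the other aromatic nitrogen, giving a 13-fold higher number from compound 2 to compound 4 (1.10 log units; beyond the scatter) when 4-bromo-2-fluorophenyl is present, a much larger step than the one seen with 2-(trifluoromethoxy)phenyl: the same change on two cores in this assay, a 1.6-fold higher number (0.19 log units; within the scatter) from compound 1 to compound 3 and a 13-fold higher number (1.10 log units; beyond the scatter) from compound 2 to compound 4, 8.1-fold (0.91 log units) apart, beyond the scatter of two such steps. Among these four compounds, the two changes therefore do not act independently, and only compound 2, which combines 4-bromo-2-fluorophenyl with hydrogen on the aromatic nitrogen, stands apart from the others.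

The compounds shown leave open whether the bromine or the fluorine of the 4-bromo-2-fluorophenyl group underlies this dependence. They also leave open how an ethyl group or a longer chain ending in an amine would behave in place of the methyl on that nitrogen.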